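This account rests on a few compounds, and the source may have more. Where it says the series, first, only, none or still open, it means among the compounds named here.

Working notes on the series. Compound 1 `CC1CC/C(=N\Nc2cccc(Br)c2)c2ncc(C(=O)O)c(=O)n21` and compound 2 `CC1CC/C(=N\Nc2ccc(I)cc2)c2ncc(C(=O)O)c(=O)n21` share one core and differ only in the aryl group on the amine nitrogen. In a functional assay on the whole organism for inhibition, with Rattus norvegicus as the target (on this read-out higher numbers stand for an effect only at larger amounts of compound and lower numbers for an effect already at smaller amounts), compound 1 gives > 320 umol/kg, which is a limit of the assay and not a number. In this assay compound 2 gives > 1000 umol/kg, again a limit rather than a number. The step that the two limits leave unreadable from compound 1 to compound 2 is therefore not readable in size; what the record holds is the limit of > 320 umol/kg in this assay, at which 1 of the 2 values shown sits, and (the limit of > 1000 umol/kg in this assay, at which 1 of the 2 values shown sits). Compound 3 `Cc1ccc(N/N=C2\CCC(C)n3c2ncc(C(=O)O)c3=O)cc1` is the next move from compound 2: methyl in place of iodo on an aromatic carbon. Among the measured compounds shown here, no measured step bears on this exchange, and both known points are limits, so no size can be carried over. In this assay the expected step is a step that the limit leaves unreadable from compound 2 to compound 3, with a limit again the most likely outcome. Compound 3 is estimated at 1500 umol/kg, range 300 umol/kg to 6000 umol/kg.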

Compound 3, dose for 50% inhibition: > 1000 umol/kg
Compound 3 was reported as a limit; the forecaster's own chance of this, stated with the estimate: 80%; the middle value is on the limit's open side.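

With compound 3 also reported as a limit, no step among compound 1, compound 2 and compound 3 can be read in this assay: the limit of > 1000 umol/kg in this assay, at which 2 of the 3 values shown sit.

The compounds shown leave open what size of effect, if any, the aryl group on the amine nitrogen has in this assay.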